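The source may report more compounds than this note shows. Statements on the series, on what has been measured and on what is new or still open speak of the compounds shown alone.

In a functional assay on PC-3 cells (Homo sapiens) for inhibition, read by sulforhodamine B assay (on this read-out higher numbers stand for weaker inhibition of growth and lower numbers for stronger inhibition of growth), compound 3 `COc1ccc(-c2ccc(-c3ccc(-c4nc5c(O)cccc5[nH]4)cc3)cc2)cc1` gives 6610 nM. This lies within the scatter of compound 1 `Cc1ccc2[nH]c(-c3ccc(-c4ccc(-c5ccc(N(C)C)cc5)cc4)cc3)nc2c1`, at 8120 nM, while compound 2 `Oc1cccc2[nH]c(-c3ccc(-c4ccc(-c5ccc(C(F)(F)F)cc5)cc4)cc3)nc12` gives a lower 2260 nM. Compound 4 `CN(C)c1ccc(-c2ccc(-c3ccc(-c4nc5c(O)cccc5[nH]4)cc3)cc2)cc1` has dimethylamino in place of methoxy on an aromatic carbon, para to a large group: dimethylamino in place of methoxy on an aromatic carbon. Among the measured compounds shown here, no measured step makes this exact change. The only one bearing on it is a 2.9-fold higher number from compound 2 to compound 3 (0.47 log units; beyond the scatter), a modest step that swaps trifluoromethyl for methoxy. Compound 1 carries dimethylamino on a differently substituted core and gives 8120 nM, so no step beyond the scatter is expected in this assay. The expected step is a 1.1-fold higher number from compound 3 to compound 4 (0.02 log units; within the scatter). The estimate for compound 4 is 7000 nM, with an expected range from 3000 nM to 16000 nM.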

Compound 4, concentration for 50% growth inhibition: 8420 nM
Beside the measured number, compound 4's estimate is 1.2-fold (0.08 log units) below it; the measured number falls inside the stated range.
By their numbers in this assay, from the lowest: compound 2; then compounds 3, 1 and 4 (each within the scatter of the next).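

In this assay, dimethylamino and methoxy at this position are not told apart, with a 1.3-fold higher number from compound 3 to compound 4 (0.11 log units; within the scatter) and only trifluoromethyl standing off from both, as a 3.7-fold higher number from compound 2 to compound 4 (0.57 log units; beyond the scatter) shows. With dimethylamino in place, 4-hydroxy-1H-benzimidazol-2-yl and 5-methyl-1H-benzimidazol-2-yl are not told apart either, with a 1.0-fold higher number from compound 1 to compound 4 (0.02 log units; within the scatter) as the step between them. No measurement shown here accounts for these results.

Whether the lower number belongs to trifluoromethyl alone stays open, since no other group at this position is shown. A nitrile or a carboxylic acid on that aromatic carbon could show which way the number moves.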